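The source may hold more compounds than are shown below. What is called first, only, known or untested is meant among the compounds shown, and "the series" means these compounds.

Measured in a functional assay on HT cells (Homo sapiens) for antiproliferative activity, read by fluorescence, with a stated time of 72 h; a lower number here means a stronger inhibitor of growth, a higher number a weaker inhibitor of growth:
- compound 1 `CC(C)c1n[nH]c2c(NCc3ccc(-c4ccccn4)cc3)nc(SCC(O)CO)nc12`: 21 nM
- compound 2 `CSc1nc(NCc2ccc(-c3ccccn3)cc2)c2[nH]nc(C(C)C)c2n1`: 783 nM
- compound 3 `CC(C)c1n[nH]c2c(NCc3ccc(-c4ccccn4)cc3)nc(SCCCO)nc12`: 109 nM

Compound 3 stands in the middle of these three numbers. Compound 4 `CC(C)c1n[nH]c2c(NCc3ccc(-c4ccccn4)cc3)nc(SCCCN(C)C)nc12` differs from it in one place: dimethylamino in place of hydroxy on a saturated chain carbon, three bonds along the chain from a sulfur. Three steps show that the chain on sulfur matters: a 37-fold higher number from compound 1 to compound 2 (1.57 log units; beyond the scatter) is large, while a 7.2-fold lower number from compound 2 to compound 3 (0.86 log units; beyond the scatter) and a 5.2-fold higher number from compound 1 to compound 3 (0.72 log units; beyond the scatter) are modest. None of them involves an amine, so they give no direction for this change. No step beyond the scatter is therefore expected in this assay, though the uncertainty is wide. The estimated step is a 1.2-fold lower number from compound 3 to compound 4 (0.08 log units; within the scatter). For compound 4 the expected value is 90 nM, with an estimated range from 25 nM to 320 nM.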

Compound 4, concentration for 50% growth inhibition: 105 nM
Estimate against measurement, compound 4: 1.2-fold (0.07 log units) below, and the stated range covers the measured number.
By their numbers in this assay, from the lowest: compound 1; then compounds 4 and 3 (each within the scatter of the next); then compound 2.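

In this assay dimethylamino in place of hydroxy on a saturated chain carbon, three bonds along the chain from a sulfur, gives a 1.0-fold lower number from compound 3 to compound 4 (0.02 log units; within the scatter) and leaves the two groups indistinguishable. The chain therefore needs no hydroxy to stay ahead of the shortest chain on sulfur, with a 7.5-fold lower number from compound 2 to compound 4 (0.87 log units; beyond the scatter) on the one side, while a 5.0-fold higher number from compound 1 to compound 4 (0.70 log units; beyond the scatter) shows that it still trails the chain carrying 1,2-dihydroxyethyl. No measurement here explains why the two groups read alike. From the compounds shown here alone, whether a carboxylic acid or a longer chain carrying the same amine would read the same at this position remains open.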